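Piperidine for pyrrolidine on the amide: expected outcome

The compounds below may be only part of what the source reports. "The series", "measured", "known", "first", "only" and "open" are said of these compounds alone.

The series shares the core seen in compound 1 `Cn1c(/C=C2\SC(=O)N(CC(=O)N3CCCCC3)C2=O)nc2ccccc21`. In a functional assay on PC-3 cells (Homo sapiens) for inhibition, read by MTT assay, with a stated time of 48 h (a lower number here means a stronger inhibitor, a higher number a weaker inhibitor), compound 1 gives only a limit, > 50000 nM. Compound 2 `CC(C)n1c(/C=C2\SC(=O)N(CC(=O)N3CCCC3)C2=O)nc2ccccc21` also returns only a limit in this assay, > 50000 nM. Compound 2 therefore sits at the limit, (the limit of > 50000 nM in this assay, at which 2 of the 2 values shown sit), with no number to place it. Compound 3 `CC(C)n1c(/C=C2\SC(=O)N(CC(=O)N3CCCCC3)C2=O)nc2ccccc21` carries piperidin-1-yl in place of pyrrolidin-1-yl on a carbonyl carbon. Among the measured compounds shown here, no measured step links this change to a shift in this assay. The expected step from compound 2 to compound 3 is a number no higher from compound 2 to compound 3 (the limit leaves the size open), none beyond the scatter. The estimate for compound 3 in this assay is 50000 nM, between 20000 nM and 150000 nM, most likely again reported only as a limit.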

Compound 3, half-maximal inhibitory concentration: > 50000 nM
Compound 3 ended at the assay's limit; the forecaster's own chance of this, stated with the estimate: 85%; the middle value lies on the limit itself.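

Among the compounds shown here, no step from compound 1 or compound 2 to compound 3 can be read in this assay as all three values are limits: the limit of > 50000 nM in this assay, at which 3 of the 3 values shown sit. The compounds shown leave open whether piperidin-1-yl in place of pyrrolidin-1-yl, or isopropyl in place of methyl, changes inhibition at all.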